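Extending the acrylamide chain on a quinazoline antiproliferative series

A few compounds are considered here, and "the series" means these few. Any claim that something is new, unique, unknown or untested is made for them only; others in the source may bear on it.

Measured compounds:
compound 1 `CCC/C=C/C(=O)Nc1cc2c(N3CCc4ccccc43)ncnc2cc1O[C@@H]1CCOC1` – 9230 nM
compound 2 `COc1cc2ncnc(N3CCCc4ccccc43)c2cc1NC(=O)C=C(C)C` – 6130 nM
compound 3 `C/C=C/C(=O)Nc1cc2c(N3CCCc4ccccc43)ncnc2cc1OC` – 7520 nM

These three compounds were tested in a functional assay on PC-3 cells (Homo sapiens) for antiproliferative activity, read by MTT assay, with a stated time of 72 h; on this read-out lower numbers stand for stronger inhibition and higher numbers for weaker inhibition. Compound 3 gives the second highest of the three numbers, and both neighbours lie within the scatter: compound 2 and compound 1 each differ from it by about a fifth either way. Compound 4 `COc1cc2ncnc(N3CCCc4ccccc43)c2cc1NC(=O)/C=C/C(C)C` is compound 3 with isopropyl in place of methyl on a double-bonded chain carbon bound to a double-bonded chain carbon. Within the data shown here, the one step that bears on this position is a 1.2-fold higher number from compound 2 to compound 3 (0.09 log units; within the scatter), a change on the same double-bonded chain carbon that left the read-out unchanged within the scatter. On that basis compound 4 is expected to show a step of a 1.0-fold lower number from compound 3 to compound 4 (0.00 log units; within the scatter), that is, no change beyond the scatter. Compound 4 is therefore estimated at 7500 nM, with a range from 3500 nM to 16000 nM.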

Compound 4, half-maximal inhibitory concentration: 8430 nM
The estimate for compound 4 lay 1.1-fold (0.05 log units) below the measured number; the measured number falls inside the stated range.
By their numbers in this assay, from the lowest: compounds 2, 3, 4 and 1 (each within the scatter of the next).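

In this assay, isopropyl in place of methyl on the double-bonded chain carbon gives a 1.1-fold higher number from compound 3 to compound 4 (0.05 log units; within the scatter) and so adds carbons at this position without a change beyond the scatter. Replacing 2-methylprop-1-en-1-yl with 3-methylbut-1-en-1-yl on the carbonyl carbon gives a 1.4-fold higher number from compound 2 to compound 4 (0.14 log units; within the scatter) and is also within the scatter, so this read-out does not separate the three chains. No available evidence explains this result.

From the compounds shown here alone, whether an amine or a carboxylic acid at this position would shift the read-out remains open. So does whether a longer chain would.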